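Notes on the epimer pair, compound 1 and compound 4

The source may report more compounds than this note shows. Statements on the series, on what has been measured and on what is new or still open speak of the compounds shown alone.

compound 1 `CN1CCC[C@@H](Cn2c(CN(C)[C@@H]3CCCc4cccnc43)nc3ccccc32)C1` at 2800 nM
compound 2 `CN1CC(Cn2c(CN(C)C3CCCc4cccnc43)nc3ccccc32)C1` at 14000 nM
compound 3 `CN1CCC(Cn2c(CN(C)C3CCCc4cccnc43)nc3ccccc32)C1` at 15000 nM

All three values come from an ADME assay on HOS cells (Homo sapiens) for cytotoxicity (a lower number here means that less compound is tolerated, a higher number that more compound is tolerated), and compound 1 is the lowest of them, with compound 2 and compound 3 each higher by more than the scatter. Those two compounds differ from compound 1 in more than configuration, so that gap says nothing about a stereocentre.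

The next compound is compound 4 `CN1CCC[C@H](Cn2c(CN(C)[C@@H]3CCCc4cccnc43)nc3ccccc32)C1` and its change from compound 1 is this: the two compounds have the same atoms and bonds and differ only in configuration as drawn: 1 of 2 stereo elements differ; a stereocentre at a saturated ring carbon is drawn R in compound 1 and S in compound 4 and no atom or bond leaves or enters. For the measured compounds named here, the only measured single-place step is a 1.1-fold higher number from compound 2 to compound 3 (0.03 log units; within the scatter) and it lies within the scatter. It changes a group and not a configuration, so it bears on this pair only loosely. Going by the values given here, no pair of opposite configuration has been measured.

On these data alone, on this evidence, no step beyond the scatter is expected in this assay and the direction remains open, with compound 1 at 2800 nM as the anchor. The expected size is a 1.4-fold higher number from compound 1 to compound 4 (0.15 log units; within the scatter) as a rough estimate. For compound 4 the estimated value is 4000 nM with an expected range from 1500 nM to 11000 nM in this assay.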

Compound 4, half-maximal cytotoxic concentration: 3600 nM
Estimate against measurement, compound 4: 1.1-fold (0.05 log units) above; measured number inside the range.
By their numbers in this assay, from the lowest: compounds 1 and 4 (each within the scatter of the next); then compounds 2 and 3 (each within the scatter of the next).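

In this assay, for the compounds shown here, the change of configuration at the saturated ring carbon gives a 1.3-fold higher number from compound 1 to compound 4 (0.11 log units; within the scatter), the first measured pair of opposite configuration. Going by these compounds alone, at this stereocentre, the drawn R and S forms are therefore not told apart by the half-maximal cytotoxic concentration, a point that the earlier compounds could not address. The reading is confined to that one stereocentre, as no atom or bond changes, and the comparison rests on this: the fact that compounds 1 and 4 differ only in the configuration as drawn.

The compounds shown leave open whether the other stereo element, drawn alike in compound 1 and compound 4, is as little felt in this assay when its configuration is changed. Also open, on these data alone, is whether configuration at the saturated ring carbon still gives no step beyond the scatter when a carboxylic acid or a longer chain is carried on the shared core.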